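Removing the Methyl from the Indole Nitrogen

This account rests on a few compounds, and the source may have more. Where it says the series, first, only, none or still open, it means among the compounds named here.

Of the compounds shown here, two have been measured in a functional assay on PC-3 cells (Homo sapiens) for cytotoxicity (on this read-out higher numbers stand for weaker inhibition and lower numbers for stronger inhibition), so far. Compound 1 `COc1ccc(Cn2cc(/C=N\NC(=O)c3c[nH]c4ccccc34)c3cc(OC)ccc32)cc1` gives 13600 nM there. Compound 2 `COc1ccc2c(c1)c(/C=N\NC(=O)c1cn(C)c3ccccc13)cn2Cc1ccc(Cl)cc1` gives 21200 nM in this assay, the higher of the two numbers, though the gap to compound 1 lies within the usual scatter. Compound 3 `COc1ccc2c(c1)c(/C=N\NC(=O)c1c[nH]c3ccccc13)cn2Cc1ccc(Cl)cc1` differs from compound 2 in one place: hydrogen in place of methyl on an aromatic nitrogen. Among the compounds with values here, no measured pair shows this change, so the step from compound 2 to compound 3 is expected to be small, with no clear direction beyond the scatter, namely a 1.3-fold lower number from compound 2 to compound 3 (0.12 log units; within the scatter). Compound 3 is therefore estimated at 16000 nM, within the range 6000 nM to 45000 nM.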

Compound 3, half-maximal inhibitory concentration: 30300 nM
Estimate against measurement, compound 3: 1.9-fold (0.28 log units) below; the measured number falls inside the stated range.
By their numbers in this assay, from the lowest: compounds 1, 2 and 3 (each within the scatter of the next, the first and the last beyond it).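

Taking the methyl off the aromatic nitrogen, 1-methyl-1H-indol-3-yl to 1H-indol-3-yl, gives a 1.4-fold higher number from compound 2 to compound 3 (0.16 log units; within the scatter) in this assay, so this change does not separate the two compounds. Chloro in place of methoxy on an aromatic carbon is the larger step, a 2.2-fold higher number from compound 1 to compound 3 (0.35 log units; beyond the scatter), though still modest. Nothing available explains either step.

Still open, going by these compounds, is whether an ethyl group or a longer chain ending in an amine on that nitrogen would move the number beyond the scatter. Also open, on these data alone, is whether the chloro step holds when the methyl is present.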